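Amino Substitution on a Chloropurine Core: Expected Cytotoxicity

The source may report more compounds than this note shows. Statements on the series, on what has been measured and on what is new or still open speak of the compounds shown alone.

Measured so far:
Compound 1, `ClCc1ccc(Cn2cnc3c(Cl)ncnc32)cc1`, > 100000 nM
Compound 2, `Nc1nc(Cl)c2ncn(Cc3ccc(CCl)cc3)c2n1`, 25700 nM
Compound 3, `ClCc1ccccc1Cn1cnc2c(Cl)ncnc21`, 7240 nM

All three compounds were tested in a functional assay on NCI-H522 cells (Homo sapiens) for cytotoxicity, read by sulforhodamine B assay, with a stated time of 48 h; on this read-out lower numbers stand for stronger inhibition of growth and higher numbers for weaker inhibition of growth. Compound 1 gives > 100000 nM, which is a limit of this assay rather than a number. Compound 2 differs from compound 1 by one change, (amino in place of hydrogen on an aromatic carbon), and this gave an at least 3.8-fold lower number from compound 1 to compound 2 (0.59 log units; beyond the scatter). Compound 3 shares its atoms with compound 1 but joins them differently; the difference between the two cores is not broken down here. Compound 3 gives 7240 nM, the lowest of the two numbers measured.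

Compound 4, `Nc1nc(Cl)c2ncn(Cc3ccccc3CCl)c2n1`, has not yet been measured. It differs from compound 3 by amino in place of hydrogen on an aromatic carbon, the same change that separates compound 1 from compound 2. Starting from the core of compound 3, compound 4 is expected to give 2000 nM, because the same change gave an at least 3.8-fold lower number from compound 1 to compound 2 (0.59 log units; beyond the scatter). Within the data shown here, this means an expected step of a 3.6-fold lower number from compound 3 to compound 4 (0.56 log units; beyond the scatter), with the range 600 nM to 6500 nM reflecting that only one earlier instance of this change is known and that it started from a limit.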

Compound 4, concentration for total growth inhibition: 9330 nM
Beside the measured number, compound 4's estimate is 4.7-fold (0.67 log units) below it, and the stated range ends below it.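

In this assay, among these compounds, the amino group on the core of compound 3 gave a 1.3-fold higher number from compound 3 to compound 4 (0.11 log units; within the scatter) and so brought no step that can be told apart from repeated measurement. The change therefore did not carry over from one core to the other, and the two steps are further apart than measurement scatter allows: the same change on two cores in this assay, an at least 3.8-fold lower number (0.59 log units; beyond the scatter) from compound 1 to compound 2 and a 1.3-fold higher number (0.11 log units; within the scatter) from compound 3 to compound 4, at least 5.0-fold (0.70 log units) apart, beyond the scatter of two such steps. Compound 1 gives > 100000 nM as a limit of the assay and not as a number, so the exact size of the earlier step stays unknown, and two cores cannot show why the steps differ or predict the change on any further core.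

The compounds shown leave open whether a methylamino group in place of the amino group would also give different steps on the two cores. They also leave open how the amino change would behave with a methoxy group in place of the chloro group.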